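Trifluoromethyl in place of chloro: notes on the series

A few compounds are considered here, and "the series" means these few. Any claim that something is new, unique, unknown or untested is made for them only; others in the source may bear on it.

- Compound 1 `CC(C)CCC1C(=O)Nc2ccc(Nc3ccc(Cl)cc3)cc21`: 2000 nM
- Compound 2 `CCCCC1(O)C(=O)Nc2ccc(Nc3ccc(Cl)cc3)cc21`: 2800 nM
- Compound 3 `CC(C)CCC1(O)C(=O)Nc2ccc(Nc3ccc(Cl)cc3)cc21`: 2700 nM

All three values come from a functional assay on A549 cells (Homo sapiens) for antiproliferative activity, read by MTT assay, with a stated time of 48 h; a higher number here means a weaker inhibitor, a lower number a stronger inhibitor. In this assay compound 3 gives 2700 nM and sits within the scatter of the other two compounds. The two measured steps that reach it are a 1.4-fold higher number from compound 1 to compound 3 (0.13 log units; within the scatter) and a 1.0-fold lower number from compound 2 to compound 3 (0.02 log units; within the scatter).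

Compound 4 `CC(C)CCC1(O)C(=O)Nc2ccc(Nc3ccc(C(F)(F)F)cc3)cc21` has not yet been measured. It differs from compound 3 as follows: trifluoromethyl in place of chloro on an aromatic carbon. This is trifluoromethyl in place of chloro on an aromatic carbon, para to a large group.

Neither measured step covers this exchange. One is hydroxy in place of hydrogen on a saturated ring carbon, the other methyl in place of hydrogen on a saturated chain carbon. All three measured compounds carry chloro, so the data hold no direct evidence for the change and no direction can be argued. The two steps bear on it only loosely, showing a series that has so far stayed flat. The expectation therefore starts from compound 3 at 2700 nM.

The expected step, a 1.1-fold lower number from compound 3 to compound 4 (0.03 log units; within the scatter), is none beyond the scatter. For compound 4 the estimated value is 2500 nM, with an expected range from 1000 nM to 6000 nM.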

Compound 4, half-maximal inhibitory concentration: 4200 nM
Compound 4: the middle estimate sits 1.7-fold (0.23 log units) below what was measured; the range from low to high includes it.
By their numbers in this assay, from the lowest: compounds 1, 3, 2 and 4 (each within the scatter of the next, the first and the last beyond it).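

In this assay, trifluoromethyl in place of chloro on an aromatic carbon, para to a large group, gives a 1.6-fold higher number from compound 3 to compound 4 (0.19 log units; within the scatter). Among the compounds shown here, this is the first measured change at this position, since compounds 1, 2 and 3 all carry chloro there, and it shows that a group of 4 heavy atoms can replace one of 1 heavy atom with a step that stays within the scatter. Nothing available here explains the step or ties it to any property of either group.

Going by these compounds, the exchange is read on only one background, that of compound 3 with its hydroxy group and chain, so it remains open whether the same exchange gives a similar step on a background without the hydroxy group, as in compound 1, or with the butyl chain of compound 2. On these data alone, it also remains open whether hydrogen, fluoro, methoxy, a nitrile, an amine or a carboxylic acid on the same aromatic carbon would stay within the scatter of compound 3, or whether one of them would give a step beyond it.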